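A Chloro in Place of Methyl: Expectation for Compound 4

The source may report more compounds than this note shows. Statements on the series, on what has been measured and on what is new or still open speak of the compounds shown alone.

Among the measured compounds shown here, compound 3 `Cc1cccc(-n2nc(-c3ccccc3)c(C=O)c2/N=C/N(C)C)c1` gives 8900 nM in a functional assay on NPC-TW01 cells (Homo sapiens) for inhibition, read by MTT assay, with a stated time of 72 h (a lower number here means a stronger inhibitor of growth, a higher number a weaker inhibitor of growth), the lowest number of the three measured so far, though the gap to compound 1 `CN(C)/C=N/c1c(C=O)c(-c2ccccc2)nn1-c1ccccc1`, which gives 9300 nM, lies within the scatter (a 1.0-fold lower number from compound 1 to compound 3 (0.02 log units; within the scatter)). Compound 2 `CN(C)/C=N/c1c(C=O)c(-c2ccccc2)nn1-c1ccccc1Cl` gives 23300 nM, and the step of a 2.6-fold lower number from compound 2 to compound 3 (0.42 log units; beyond the scatter) stands beyond the scatter. Compound 4 `CN(C)/C=N/c1c(C=O)c(-c2ccccc2)nn1-c1cccc(Cl)c1` differs from compound 3 by chloro in place of methyl on an aromatic carbon. For the measured compounds named here, two measured steps bear on this change. Chloro in place of hydrogen gave a 2.5-fold higher number from compound 1 to compound 2 (0.40 log units; beyond the scatter), a modest rise, while methyl in place of hydrogen gave a 1.0-fold lower number from compound 1 to compound 3 (0.02 log units; within the scatter), nothing beyond the scatter; the chloro of compound 2 sits on a different carbon than the one in compound 4, so the comparison is loose. On this basis a small rise in this assay is expected for compound 4, a 1.6-fold higher number from compound 3 to compound 4 (0.20 log units; within the scatter), which may still fall within the scatter. Compound 4 is therefore estimated at 14000 nM, with a range from 6000 nM to 35000 nM.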

Compound 4, concentration for 50% growth inhibition: 6400 nM
Compound 4: middle estimate off by 2.2-fold (0.34 log units), on the high side, and the stated range covers the measured number.
By their numbers in this assay, from the lowest: compounds 4, 3 and 1 (each within the scatter of the next); then compound 2.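

In this assay, the step with chloro in place of methyl at this carbon, meta to a large group, stays within the scatter (a 1.4-fold lower number from compound 3 to compound 4 (0.14 log units; within the scatter)), as does the step with chloro in place of hydrogen (a 1.5-fold lower number from compound 1 to compound 4 (0.16 log units; within the scatter)), so hydrogen, methyl and chloro at this carbon are not told apart by these numbers. The step between the two chlorophenyl groups lies beyond the scatter (a 3.6-fold lower number from compound 2 to compound 4 (0.56 log units; beyond the scatter)), which ties the higher number of compound 2 to the 2-chlorophenyl group rather than to chloro as such. No measurement at hand accounts for this difference between the two chlorophenyl groups.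

The compounds shown leave open whether a methoxy group, an amine or a carboxylic acid at this carbon would stand apart from hydrogen, methyl and chloro. They also leave open whether a methyl group on the neighbouring-numbered 2-position, as in a 2-methylphenyl group, would follow the 2-chlorophenyl group of compound 2.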